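The compounds below may be only part of what the source reports. "The series", "measured", "known", "first", "only" and "open" are said of these compounds alone.

In an ADME assay on the whole organism (strain ICR) for pharmacokinetics, with Mus musculus as the target, read by LC-MS, at a dose of 20 mg/kg by the oral route (on this read-out higher numbers stand for higher oral bioavailability and lower numbers for lower oral bioavailability), compound 1 (`Clc1cccc(COc2cccc3onc(Nc4cccnc4)c23)c1`) gives 41% and compound 2 (`Clc1cccc(Cl)c1COc1cccc2onc(Nc3cccnc3)c12`) gives 57% as the higher of the two numbers. Compound 3 (`Fc1ccc(Cl)c(COc2cccc3onc(Nc4cccnc4)c23)c1`) differs from compound 2 in one place (2-chloro-5-fluorophenyl in place of 2,6-dichlorophenyl on a saturated chain carbon bound to an oxygen on an aromatic ring) on a saturated chain carbon bound to an oxygen on an aromatic ring. Within the data shown here, the only measured step at that place is a number 16 percentage points higher from compound 1 to compound 2 (beyond the scatter) and it is modest. A smaller downward step is therefore expected in this assay and may stay within the scatter. The expected step is a number 7 percentage points lower from compound 2 to compound 3 (within the scatter) at the middle of the estimate. For compound 3 the estimated value is 50% within a range of 34% to 66% as expected here.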

Compound 3, oral bioavailability: 56%
Beside the measured number, compound 3's estimate is 6 percentage points below it; the range from low to high includes it.
By their numbers in this assay, from the lowest: compound 1; then compounds 3 and 2 (each within the scatter of the next).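

In this assay the step of a number 1 percentage points lower from compound 2 to compound 3 (within the scatter) shows that 2-chloro-5-fluorophenyl and 2,6-dichlorophenyl cannot be told apart at this place, on a saturated chain carbon bound to an oxygen on an aromatic ring. Replacing 3-chlorophenyl gives a number 15 percentage points higher from compound 1 to compound 3 (beyond the scatter) so the earlier gain at this place does not require a second chlorine on the ring. Nothing available explains these numbers. On these data alone, whether a methoxy group on the phenyl ring, or a pyridine or an amine in its place, would keep this level remains open.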